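This account rests on a few compounds, and the source may have more. Where it says the series, first, only, none or still open, it means among the compounds named here.

Working notes on the series in a functional assay on Hs-578T cells (Homo sapiens) for antiproliferative activity; a lower number here means a stronger inhibitor of growth, a higher number a weaker inhibitor of growth. Compound 1 `COC(=O)CCCCCCCCCCCCCC/C=C1\CC(CO)(COC(=O)C(C)(C)C)OC1=O` gives > 10 ug/mL, which is a limit and not a number. Compound 2 `CC(=O)OCCCCCCCCCCCCCCC/C=C1\CC(CO)(COC(=O)C(C)(C)C)OC1=O` gives > 10 ug/mL, also a limit. Compound 1 therefore stands at the limit of > 10 ug/mL in this assay, at which 2 of the 3 values shown sit. Compound 3 `CC(C)(C)C(=O)OCCCCCCCCCCCCCCC/C=C1\CC(CO)(COC(=O)C(C)(C)C)OC1=O` alone gives a number, 5.24 ug/mL.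

Compound 4 `CC(=O)NCCCCCCCCCCCCCCC/C=C1\CC(CO)(COC(=O)C(C)(C)C)OC1=O` carries acetamidomethyl in place of methoxycarbonyl on a saturated chain carbon, ten or more bonds along the chain from a double-bonded chain carbon. The count reads (acetamidomethyl in place of methoxycarbonyl on a saturated chain carbon, ten or more bonds along the chain from a double-bonded chain carbon).

Going by the values given here, three measured steps bear on this change. At the same place, the acetoxymethyl of compound 2 gives a step that the two limits leave unreadable from compound 1 to compound 2. The other two are an at least 1.9-fold lower number from compound 1 to compound 3 (0.28 log units; that floor lies within the scatter) and an at least 1.9-fold lower number from compound 2 to compound 3 (0.28 log units; that floor lies within the scatter). Neither floor goes beyond the scatter, and compound 4 has no tert-butyl, the group that compound 3 carries in the second of these steps.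

No step beyond the scatter is therefore expected in this assay, and no direction can be given. The expected step is a step that the limit leaves unreadable from compound 1 to compound 4. For compound 4 the estimated value is 12 ug/mL, within an expected range of 5 ug/mL to 25 ug/mL. A report as a limit is expected to be more likely than a number.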

Compound 4, concentration for 50% growth inhibition: > 10 ug/mL
Compound 4 was reported as a limit; the forecaster's own chance of this, stated with the estimate: 60%; the middle value does not contradict the limit.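

In this assay compound 4 gives (> 10 ug/mL), which is a limit and not a number, so acetamidomethyl on this saturated chain carbon brings no readable value, and its amide hydrogen adds no readable gain over the methoxycarbonyl and acetoxymethyl ends. Going by these compounds alone, the steps from compound 1 and from compound 2 to compound 4 cannot be read; the only readable step is (an at least 1.9-fold higher number from compound 3 to compound 4 (0.28 log units; that floor lies within the scatter)), so even this comparison does not establish a real gap between acetamido and ((tert-butyl)carbonyl)oxy at this place. Compound 3 remains the one compound that goes against the shared limit, which now covers most of the series: the limit of > 10 ug/mL in this assay, at which 3 of the 4 values shown sit.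

On these data alone, how far compound 1, compound 2 and compound 4 actually lie past their limits remains open, and so does whether the tert-butyl of compound 3 matters on its own. A pivalamido end, a carboxylic acid or a primary amine at the same place would test whether a number depends on that tert-butyl or on the ester link.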